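The source may hold more compounds than are shown below. What is called first, only, known or untested is meant among the compounds shown, and "the series" means these compounds.

Working notes on the series. The series is followed in an assay on HEK293 cells for positive allosteric modulation of metabotropic glutamate receptor 5 (Homo sapiens), read by FLIPR, with a stated time of 1 h; a lower number here means that less compound is needed, a higher number that more compound is needed for the effect. Compound 1 `Cc1cccc(C#Cc2nc3c(s2)C(=O)NCC3)c1` carries an unsubstituted lactam on the shared core; in this assay compound 1 gives only a limit, > 10000 nM. Compound 2 `CCN1CCc2nc(C#Cc3ccccc3)sc2C1` carries ethyl on the ring amine; in this assay compound 2 likewise gives only a limit, > 10000 nM. So compound 2 sits at the limit of the assay, where two of the three values shown sit (the limit of > 10000 nM in this assay, at which 2 of the 3 values shown sit), and no number for it is known. Compound 3 `O=C(C1CC(F)(F)C1)N1CCc2nc(C#Cc3cccc(F)c3)sc2C1` gives 2.5 nM in this assay.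

The step to compound 4 `O=C(C1CCCC1)N1CCc2nc(C#Cc3ccccc3)sc2C1` puts (cyclopentylcarbonyl in place of ethyl on an amine nitrogen in a ring). For the measured compounds named here, no measured pair differing in this one place exists, so the size of the step is an expectation only. A large step in this assay is expected, toward a lower number, well beyond the scatter, because compound 3 gives 2.5 nM. Compound 4 is estimated at 10 nM, expected between 2 nM and 50 nM. The expected step is an at least 1000-fold lower number from compound 2 to compound 4 (3.00 log units; beyond the scatter).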

Compound 4, half-maximal effective concentration: 19 nM
For compound 4 the middle estimate is 1.9-fold (0.28 log units) below the measured one, and the stated range covers the measured number.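

Working at the amine nitrogen in a ring, with the rest of the structure unchanged, cyclopentylcarbonyl in place of ethyl in this assay gives an at least 520-fold lower number from compound 2 to compound 4 (2.72 log units; beyond the scatter). For the compounds shown here, this is the first one-place step, and it shows that the group on this nitrogen alone can take a compound from the limit of the assay to a measurable value. Compound 2 gives only a limit, so the step is a bound and its true size is not known: the limit of > 10000 nM in this assay, at which 2 of the 4 values shown sit.

The change brings in a carbonyl, with its hydrogen-bond acceptor, and a five-membered ring together, so the compounds shown do not tell which of the two carries the step. Cyclopentylmethyl or acetyl on the same nitrogen would separate the two.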